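Aryloxy variation on the imidazoline series: intrinsic activity notes

The compounds below may be only part of what the source reports. "The series", "measured", "known", "first", "only" and "open" are said of these compounds alone.

Measured so far:
compound 1 `CCOc1ccccc1OC(C)C1=NCCN1` — 0.45
compound 2 `CC(C)Oc1ccccc1OC(C)C1=NCCN1` — 0.7
compound 3 `C=CCc1cccc(CC=C)c1OC(C)C1=NCCN1` — 0.9

In an assay on CHO cells with Alpha-2C adrenergic receptor (Homo sapiens) as the target (on this read-out higher numbers stand for larger maximal responses and lower numbers for smaller maximal responses), compound 2 gives 0.7, the second highest of the three numbers; compound 3 stands above it and compound 1 below it. Within the data shown here, the one single-place step measured so far is a number 0.25 higher from compound 1 to compound 2 (beyond the scatter). Compound 4 `CC(Oc1ccccc1OC1CC1)C1=NCCN1` has not yet been measured; it differs from compound 2 by cyclopropyl in place of isopropyl on an oxygen on an aromatic ring. The counted difference keeps the number of heavy atoms and only closes a ring, so a small step, if any, is expected in this assay, with direction uncertain. The value of compound 4 in this assay is estimated at 0.6 (range 0.4 to 0.85), which is expected to mean a step of a number 0.10 lower from compound 2 to compound 4 (within the scatter).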

Compound 4, intrinsic activity: the largest response reached, as a fraction of the reference agonist's: 0.7
For compound 4 the middle estimate is 0.10 below the measured one; the range from low to high includes it.
By their numbers in this assay, from the lowest: compound 1; then compounds 2 and 4 (each within the scatter of the next); then compound 3.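

In this assay cyclopropyl in place of isopropyl on the oxygen on the aromatic ring gives no change at the digits printed from compound 2 to compound 4 (within the scatter) and thus leaves the read-out unmoved at this place, even with a three-membered ring added. Cyclopropyl in place of ethyl gives a number 0.25 higher from compound 1 to compound 4 (beyond the scatter) and matches a number 0.25 higher from compound 1 to compound 2 (beyond the scatter) in size, so the rise over ethyl is not confined to isopropyl. No evidence at hand explains why the two groups read alike. As far as these compounds go, whether a cyclobutyl or a tert-butyl on that oxygen would read the same stays open.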